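Epimer at the chain carbon in a dichlorinated EZH2 series

This account rests on a few compounds, and the source may have more. Where it says the series, first, only, none or still open, it means among the compounds named here.

Among the measured compounds shown here, compound 1 `Cc1cc(C)c(CN2CCc3c(Cl)cc([C@@H](CO)[C@H]4CCCO4)c(Cl)c3C2=O)c(=O)[nH]1` is the only member of this set with a single number: in an assay for inhibition of histone-lysine N-methyltransferase EZH2 variant Y641N (Homo sapiens), read by scintillation counting, with a stated time of 60 min, in the presence of a further agent that is not named here (a higher number here means a weaker inhibitor, a lower number a stronger inhibitor), compound 1 gives 110 nM. For the measured compounds named here, compound 2 `Cc1cc(C)c(CN2CCc3c(Cl)cc(C(CO)C4CCOC4)c(Cl)c3C2=O)c(=O)[nH]1`, drawn without defined configuration, is recorded in this assay at 150 nM; 0.38 nM (2 entries), two entries far apart from each other (the several entries of compound 2 in this assay, 150 nM; 0.38 nM (2 entries)); that spread is noted but no single step can be drawn from it, and no step between measured compounds is available here.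

Compound 3 `Cc1cc(C)c(CN2CCc3c(Cl)cc([C@H](CO)[C@H]4CCCO4)c(Cl)c3C2=O)c(=O)[nH]1` is the epimer of compound 1: the two compounds have the same atoms and bonds and differ only in configuration as drawn: 1 of 2 stereo elements differ; a stereocentre at a saturated chain carbon is drawn S in compound 1 and R in compound 3. Inversion at a single stereocentre in this assay is expected to move the inhibition constant well beyond the scatter, and the discordant entries of compound 2 the several entries of compound 2 in this assay, 150 nM; 0.38 nM (2 entries) show that a far stronger inhibitor exists within closely related material, so the change is expected to run toward stronger inhibition. For compound 3 the estimated value in this assay is 8 nM, with a range of 0.5 nM to 150 nM, an expected step of a 14-fold lower number from compound 1 to compound 3 (1.14 log units; beyond the scatter).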

Compound 3, inhibition constant: 8 nM
Estimate against measurement, compound 3: no gap at the digits printed; measured number inside the range.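

In this assay, inversion at the saturated chain carbon, with the other stereocentre left as drawn, gives a 14-fold lower number from compound 1 to compound 3 (1.14 log units; beyond the scatter). The configuration at this one carbon therefore matters to the inhibition constant, with the R drawing the stronger of the two in this pair. This could not be read before. Among the compounds shown here, no step between measured compounds existed at that point. The step can be assigned to this stereocentre alone on the strength of one fact: the fact that compounds 1 and 3 differ only in the configuration as drawn

On these data alone, still unresolved is how the widely separated results for compound 2, drawn without defined configuration, relate to this stereochemical step, and the pair does not settle which of them better describes that material: the several entries of compound 2 in this assay, 150 nM; 0.38 nM (2 entries) Also open are whether the R preference at the chain carbon persists when the hydroxyl group on that chain is replaced by a primary amine or a carboxylic acid, and whether inversion at the other stereocentre, unchanged between these two compounds, moves the inhibition constant to a similar extent.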